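The source may hold more compounds than are shown below. What is called first, only, known or untested is meant among the compounds shown, and "the series" means these compounds.

Compound 1 (`CC1=CCC[C@H]2[C@](C)(CC3=CC(=O)C=CC3=O)[C@@H](C)CC[C@]12C`): 16700 nM
Compound 2 (`CC(C)C[C@H](NC1=CC(=O)C=C(C(C)(C)C)C1=O)C(=O)O`): 84900 nM

In a functional assay on MDA-MB-453 cells (Homo sapiens) for cytotoxicity, read by MTT assay, with a stated time of 72 h (on this read-out higher numbers stand for weaker inhibition and lower numbers for stronger inhibition), compound 2 gives 84900 nM as the higher of the two numbers, and compound 1 at 16700 nM lies lower by a gap beyond the scatter. The two compounds differ in more than one place, so this gap says nothing about the next change.

Compound 3 (`CSCC[C@H](NC1=CC(=O)C=C(C(C)(C)C)C1=O)C(=O)O`) is still unmeasured. It differs from compound 2 by (methylsulfanyl)methyl in place of isopropyl on a saturated chain carbon, two bonds along the chain from an amine nitrogen and a carbonyl carbon and carries (methylsulfanyl)methyl in place of isopropyl on a saturated chain carbon, two bonds along the chain from an amine nitrogen and a carbonyl carbon. For the measured compounds named here, no measured pair shows this change, so only a small shift is expected in this assay and none beyond the scatter. The expected small downward move is a 1.3-fold lower number from compound 2 to compound 3 (0.12 log units; within the scatter) in this estimate. For compound 3 the estimated value is 65000 nM within an expected range of 30000 nM to 130000 nM in this assay.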

Compound 3, half-maximal inhibitory concentration: 151000 nM
Compound 3: the middle estimate sits 2.3-fold (0.37 log units) below what was measured; the whole stated range lies below it.
By their numbers in this assay, from the lowest: compound 1; then compounds 2 and 3 (each within the scatter of the next).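

For the compounds shown here, compound 2 and compound 3 give the first comparison that differs in one place: in this assay, (methylsulfanyl)methyl in place of isopropyl on the saturated chain carbon gives a 1.8-fold higher number from compound 2 to compound 3 (0.25 log units; within the scatter). At this position, then, exchanging one of these groups for the other, with the same count of heavy atoms and one sulfur entering, leaves the number within the usual scatter, although a single pair cannot show how general this is. Nothing in the data on hand accounts for the size of this step.

The compounds shown leave open whether a benzyl group, a hydroxymethyl group or a longer chain ending in an amine on this carbon would move the number beyond the scatter. They also leave open whether a methoxy group in place of the methylsulfanyl part would give a number close to that of compound 3.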